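A few compounds are considered here, and "the series" means these few. Any claim that something is new, unique, unknown or untested is made for them only; others in the source may bear on it.

Working notes on the series. In a functional assay on Jurkat cells (Homo sapiens) for cytotoxicity, read by MTT assay, with a stated time of 24 h (on this read-out higher numbers stand for an effect only at larger amounts of compound and lower numbers for an effect already at smaller amounts), compound 1 (`CCOC(=O)c1cc([Se]c2ccc3cc(OC)ccc3c2)c2cc(OC)ccc2n1`) gives 31300 nM and compound 2 (`CCOC(=O)c1cc([Se]c2ccc3ccccc3c2)c2cc(OC)ccc2n1`) gives 50700 nM. Among the measured compounds shown here, these are the only two numbers so far, and they do not separate: a 1.6-fold higher number from compound 1 to compound 2 (0.21 log units; within the scatter). For the measured compounds named here, compound 1 therefore stands level with its sole neighbour.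

Compound 3 (`CCOC(=O)c1cc([Se]c2ccc3cc(OC)ccc3c2)c2cc(Cl)ccc2n1`) keeps the core of compound 1 with one change, chloro in place of methoxy on an aromatic carbon. Going by the values given here, the one measured step, a 1.6-fold higher number from compound 1 to compound 2 (0.21 log units; within the scatter), removes the other methoxy of compound 1, so it bears on this change only indirectly. Among the compounds with values here, no measured step covers the methoxy replaced here. With that single small step as the guide, no shift beyond the scatter is expected in this assay, and no direction can be assigned. The expected step is a 1.0-fold lower number from compound 1 to compound 3 (0.02 log units; within the scatter). The estimate for compound 3 is 30000 nM, with an expected range from 12000 nM to 75000 nM.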

Compound 3, half-maximal effective concentration: 29200 nM
The estimate for compound 3 lay 1.0-fold (0.01 log units) above the measured number; low and high end bracket the measured number.
By their numbers in this assay, from the lowest: compounds 3, 1 and 2 (each within the scatter of the next).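

Among the compounds shown here, this is the first measured change at the methoxy that compound 2 also carries. In this assay, chloro in place of methoxy on this aromatic carbon gives a 1.1-fold lower number from compound 1 to compound 3 (0.03 log units; within the scatter), so the exchange of two heavy atoms, one of them a hydrogen-bond acceptor, for a single chlorine does not separate the pair. No measurement of any property of these groups bears on this result.

On these data alone, what an amine or a carboxylic acid on this carbon would do stays open, so the reading covers only methoxy and chloro here. Whether any change at either methoxy position can move the number beyond the scatter also remains unresolved, since the steps shown so far all lie within it.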